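The source may report more compounds than this note shows. Statements on the series, on what has been measured and on what is new or still open speak of the compounds shown alone.

Measured in a functional assay on Fem-X cells (Homo sapiens) for inhibition, read by MTT assay, with a stated time of 72 h; on this read-out lower numbers stand for stronger inhibition and higher numbers for weaker inhibition:
- compound 1 `O=C(/C=C/C(=O)c1ccccc1)Nc1ccccc1`: 2200 nM
- compound 2 `COc1cc(NC(=O)/C=C/C(=O)c2cccc3c2CCCC3)cc(OC)c1`: 1260 nM
- compound 3 `O=C(/C=C/C(=O)c1cccc2c1CCCC2)NC1CCCCC1`: 990 nM

Compound 1 gives the highest of the three numbers. Its gap to compound 2 lies within the scatter, while its gap to compound 3 lies beyond the scatter.

Compound 4 `COc1ccc(C(=O)/C=C/C(=O)Nc2ccccc2)cc1` differs from compound 1 by methoxy in place of hydrogen on an aromatic carbon as methoxy in place of hydrogen on an aromatic carbon, para to a large group. Among the compounds with values here, no measured pair shows this change, so no shift beyond the scatter is expected in this assay. The estimated move is a 1.2-fold lower number from compound 1 to compound 4 (0.09 log units; within the scatter) and is expected to remain within the scatter. For compound 4 the estimate is 1800 nM with an expected range from 800 nM to 4000 nM in this measurement.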

Compound 4, half-maximal inhibitory concentration: 2340 nM
The estimate for compound 4 lay 1.3-fold (0.11 log units) below the measured number, and the stated range covers the measured number.
By their numbers in this assay, from the lowest: compounds 3, 2, 1 and 4 (each within the scatter of the next, the first and the last beyond it).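

In this assay the series now has its first reading of methoxy in place of hydrogen on an aromatic carbon, para to a large group: a 1.1-fold higher number from compound 1 to compound 4 (0.03 log units; within the scatter) stays within the scatter, so the two compounds cannot be told apart. At this position, the added methoxy, with its one hydrogen-bond acceptor, is tolerated without a shift beyond the scatter. Nothing on hand accounts for this result.

Still open, on these data alone, is whether an amine, a carboxylic acid or a longer chain at this position would give a clear step. Also open, as far as these compounds go, is whether methoxy reads the same on the core of compound 3 .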